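From Dimethylphenyl to Vinylphenyl on the Chain

A few compounds are considered here, and "the series" means these few. Any claim that something is new, unique, unknown or untested is made for them only; others in the source may bear on it.

In a functional assay on A-431 cells (Homo sapiens) for cytotoxicity (on this read-out higher numbers stand for an effect only at larger amounts of compound and lower numbers for an effect already at smaller amounts), compound 1 `COC1=C(C)C(=O)/C(=C(O)/C=C/c2ccc(O)cc2)C(=O)C1(C)C` gives 14.9 ug/mL, while compound 2 `COC1=C(C)C(=O)/C(=C(O)/C=C/c2cc(C)cc(C)c2)C(=O)C1(C)C` gives 4 ug/mL. That is the lower of the two numbers, so compound 2 shows its effect at the smaller amount.

Compound 3 `C=Cc1ccccc1/C=C/C(O)=C1/C(=O)C(C)=C(OC)C(C)(C)C1=O` keeps the shared core of compound 2 and differs at one place, on a double-bonded chain carbon bound to a double-bonded chain carbon: 2-vinylphenyl in place of 3,5-dimethylphenyl on a double-bonded chain carbon bound to a double-bonded chain carbon.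

Within the data shown here, only one measured step bears on this change: a 3.7-fold lower number from compound 1 to compound 2 (0.57 log units; beyond the scatter). It happened at the same place, but it removed a 4-hydroxyphenyl group. Among the measured compounds shown here, the new swap leaves the hydrogen-bond counts unchanged, and no measured compound carries a vinyl group. From the compounds shown here alone, that earlier step is therefore only a loose guide, and the direction of any change stays open. In this assay, no step beyond the scatter is expected. The estimated step is a 1.3-fold higher number from compound 2 to compound 3 (0.10 log units; within the scatter). For compound 3 the estimated value is 5 ug/mL, with an expected range from 2 ug/mL to 13 ug/mL.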

Compound 3, concentration for half-maximal effect: 2.6 ug/mL
Estimate against measurement, compound 3: 1.9-fold (0.28 log units) above, and the stated range covers the measured number.
By their numbers in this assay, from the lowest: compounds 3 and 2 (each within the scatter of the next); then compound 1.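

At this position on the chain, this assay does not separate two quite different phenyl groups: putting 2-vinylphenyl in place of 3,5-dimethylphenyl gives a 1.5-fold lower number from compound 2 to compound 3 (0.19 log units; within the scatter), a difference within the scatter, so compound 2 and compound 3 cannot be ranked against each other. The same place therefore accepts a change in both the kind of substituent on the ring and the way it is arranged, without a readable shift in the number. Measured against 4-hydroxyphenyl, the new group gives a 5.7-fold lower number from compound 1 to compound 3 (0.76 log units; beyond the scatter), beyond the scatter, so the gap to compound 1 now holds for two different replacement groups rather than for one alone, and no measurement here explains why these groups read as they do.

The compounds shown leave open whether the double bond of the vinyl group matters at all, which an ethyl group on the same ring could test, and whether the ring's substitution pattern counts separately, since compound 2 and compound 3 differ in both at once. From the compounds shown here alone, how a phenyl ring carrying an amine or a carboxylic acid would read at this place also remains unknown.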